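Ester for amide on the shared core

A few compounds are considered here, and "the series" means these few. Any claim that something is new, unique, unknown or untested is made for them only; others in the source may bear on it.

- compound 1 `CNC(=O)/C=C/c1ccncc1-c1ccc2ccccc2c1` gives 9340 nM
- compound 2 `CCOC(=O)/C=C/c1ccncc1-c1ccc2[nH]ccc2c1` gives > 10000 nM as a limit

For the measured compounds named here, in a functional assay on MCF7 cells (Homo sapiens) for inhibition, read by sulforhodamine B assay, with a stated time of 72 h (a higher number here means a weaker inhibitor of growth, a lower number a stronger inhibitor of growth), compound 1 gives 9340 nM as the only actual number so far. Compound 2 stands at > 10000 nM which is a limit of the assay and not a number. Going by the values given here, compound 3 `CCOC(=O)/C=C/c1ccncc1-c1ccc2ccccc2c1` keeps the core of compound 1 and carries ethoxy in place of methylamino on a carbonyl carbon as its one change. Among the compounds with values here, no measured step tests this change in this assay so far. The expected step of a 1.2-fold lower number from compound 1 to compound 3 (0.07 log units; within the scatter) is none beyond the scatter. The estimate for compound 3 is 8000 nM (range 3000 nM to 20000 nM).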

Compound 3, concentration for 50% growth inhibition: 8320 nM
The estimate for compound 3 lay 1.0-fold (0.02 log units) below the measured number; the range from low to high includes it.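

In this assay, for the compounds shown here, the first measured step at this place, ethoxy in place of methylamino on a carbonyl carbon, gives a 1.1-fold lower number from compound 1 to compound 3 (0.05 log units; within the scatter). The hydrogen-bond donor of methylamino therefore leaves with no step beyond the scatter, so this assay does not separate the amide from the ester on the shared core. Compound 2 offers no number for comparison, as its value is a limit of the assay: the limit of > 10000 nM in this assay, at which 1 of the 3 values shown sits.

From the compounds shown here alone, whether any group on this carbonyl carbon moves the number beyond the scatter stays open. A carboxylic acid or a longer chain in place of ethoxy would test this.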